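This account rests on a few compounds, and the source may have more. Where it says the series, first, only, none or still open, it means among the compounds named here.

Measured in an ADME assay on L02 cells (Homo sapiens) for cytotoxicity, read by MTT assay, with a stated time of 72 h; a higher number here means a weaker inhibitor, a lower number a stronger inhibitor:
- compound 1 `C=CC(=O)Nc1cc2c(Nc3ccc(OCc4cccc(F)c4)c(Cl)c3)ncnc2cc1OCc1cn(CCCC(=O)NO)nn1`: > 25000 nM
- compound 2 `C=CC(=O)Nc1cc2c(Nc3cccc(Cl)c3F)ncnc2cc1OCc1cn(CCCCC(=O)NO)nn1`: > 25000 nM
- compound 3 `CN(C)C/C=C/C(=O)Nc1cc2ncnc(Nc3ccc(F)c(Cl)c3)c2cc1O[C@@H]1CCOC1`: 1620 nM

Compound 1 stands at a limit of the assay, > 25000 nM, and this is not an exact number. Compound 2 also stands at a limit, > 25000 nM. Compound 3 has an exact number, 1620 nM.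

The next compound to be tested is compound 4 `C=CC(=O)Nc1cc2c(Nc3ccc(F)c(Cl)c3)ncnc2cc1OCc1cn(CCCC(=O)NO)nn1`, which differs from compound 1 in one place: fluoro in place of (3-fluorobenzyl)oxy on an aromatic carbon. Put simply, the (3-fluorobenzyl)oxy group of compound 1 is gone in compound 4, and a fluoro group takes over its place.

Among the measured compounds shown here, no measured pair shows a step of this kind, so its size in this assay can only be judged loosely. For compound 1, the nearest guide is the limit of > 25000 nM in this assay, at which 2 of the 3 values shown sit. On that ground, the expected step is small: none beyond the scatter, or at most a modest move towards stronger inhibition. The estimated change is a number no higher from compound 1 to compound 4 (the limit leaves the size open). For compound 4, the estimated value is 25000 nM, with an expected range of 10000 nM to 50000 nM.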

Compound 4, half-maximal inhibitory concentration: > 25000 nM
Compound 4: only a limit was reported; the forecaster's own chance of this, stated with the estimate: 60%; the middle value lies on the limit itself.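

In this assay compound 4 gives > 25000 nM, which is a limit of the assay and not an exact number. Compound 1 also stands at a limit, so no step can be read from compound 1 to compound 4. The compounds shown leave open how much swapping (3-fluorobenzyl)oxy for fluoro changes the true value in this assay, and where either compound truly stands.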